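A few compounds are considered here, and "the series" means these few. Any claim that something is new, unique, unknown or untested is made for them only; others in the source may bear on it.

Working notes on the series in a functional assay on Ishikawa cells (Homo sapiens) for antiproliferative activity, read by CCK-8 assay, with a stated time of 48 h; a lower number here means a stronger inhibitor, a higher number a weaker inhibitor. Compound 1 `CNC(=O)/C=C/CNCCOc1ccc(Oc2c(-c3ccc(F)cc3)sc3cc(O)ccc23)cc1` gives 15500 nM, compound 2 `CN(C)C(=O)/C=C/CNCCOc1ccc(Oc2c(-c3ccc(F)cc3)sc3cc(O)ccc23)cc1` gives 11900 nM, and compound 3 `C=CC(=O)N1CC(Oc2ccc(Oc3c(-c4ccc(F)cc4)sc4cc(O)ccc34)cc2)C1` gives 12300 nM. These three values lie within the scatter of each other, so compound 3 stands level with the other two.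

Compound 4 `C=C(C)C(=O)N1CC(Oc2ccc(Oc3c(-c4ccc(F)cc4)sc4cc(O)ccc34)cc2)C1` differs from compound 3 by a single change, methyl in place of hydrogen on a double-bonded chain carbon bound to a carbonyl carbon.

Within the data shown here, three measured steps bear on this. The nearest is also a methyl in place of hydrogen, though at a different place, on an amide-type nitrogen, and it reads a 1.3-fold lower number from compound 1 to compound 2 (0.11 log units; within the scatter). Two larger exchanges on the oxygen on an aromatic ring read a 1.3-fold lower number from compound 1 to compound 3 (0.10 log units; within the scatter) and a 1.0-fold higher number from compound 2 to compound 3 (0.01 log units; within the scatter). With no measured step beyond the scatter, none beyond it is expected in this assay, and no direction can be assigned. The expected step is a 1.0-fold lower number from compound 3 to compound 4 (0.01 log units; within the scatter). For compound 4 the estimated value is 12000 nM, with an expected range of 6500 nM to 22000 nM.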

Compound 4, half-maximal inhibitory concentration: 14200 nM
Compound 4: the middle estimate sits 1.2-fold (0.07 log units) below what was measured; low and high end bracket the measured number.
By their numbers in this assay, from the lowest: compounds 2, 3, 4 and 1 (each within the scatter of the next).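

In this assay, methyl in place of hydrogen on a double-bonded chain carbon bound to a carbonyl carbon reads a 1.2-fold higher number from compound 3 to compound 4 (0.06 log units; within the scatter), so this position now has a measured step of its own, and that step stays inside the scatter. The 1-((1-methylethenyl)carbonyl)azetidin-3-yl group on the oxygen on an aromatic ring also stands level with the two longer chains it replaces, reading a 1.2-fold higher number from compound 2 to compound 4 (0.08 log units; within the scatter) and a 1.1-fold lower number from compound 1 to compound 4 (0.04 log units; within the scatter). No supporting measurement accompanies these results, so the series offers no account of them.

The compounds shown leave open whether a larger group at this place, such as an ethyl or a phenyl, would produce a step beyond the scatter. On these data alone, whether a nitrile or a carboxylic acid there would do so also remains open.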